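The source may report more compounds than this note shows. Statements on the series, on what has been measured and on what is new or still open speak of the compounds shown alone.

Measured compounds in an assay for inhibition of Dihydrofolate reductase (Bos taurus), using NADPH; on this read-out lower numbers stand for stronger inhibition and higher numbers for weaker inhibition:
compound 1 `Cc1ccc(N2C(N)=NC(N)=NC23CCCCC3)cc1`, a limit of the assay: > 100000 nM
compound 2 `CC1(C)N=C(N)N=C(N)N1Cc1ccccc1`: 19500 nM
compound 3 `CC1(C)N=C(N)N=C(N)N1Cc1ccc(Cl)cc1`: 29900 nM

Compound 3 has the highest of the two numbers; the nearest is compound 2, with a 1.5-fold higher number from compound 2 to compound 3 (0.19 log units; within the scatter), so the two stand within the scatter of each other. The value of compound 1 is a limit only, (the limit of > 100000 nM in this assay, at which 1 of the 3 values shown sits).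

Compound 4 `Cc1ccc(CN2C(N)=NC(N)=NC2(C)C)cc1` is not yet measured. Its change from compound 3 is methyl in place of chloro on an aromatic carbon. Among the compounds with values here, the one measured step bearing on this position is a 1.5-fold higher number from compound 2 to compound 3 (0.19 log units; within the scatter), which lay within the scatter. No step beyond the scatter is therefore expected in this assay; the estimated step is a 1.2-fold lower number from compound 3 to compound 4 (0.08 log units; within the scatter). For compound 4 the expected value is 25000 nM, with a range from 10000 nM to 65000 nM.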

Compound 4, half-maximal inhibitory concentration: 24600 nM
Compound 4: middle estimate off by 1.0-fold (0.01 log units), on the high side; low and high end bracket the measured number.
By their numbers in this assay, from the lowest: compounds 2, 4 and 3 (each within the scatter of the next). At a limit, above all of these: compound 1.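

Methyl in place of chloro (a 1.2-fold lower number from compound 3 to compound 4 (0.08 log units; within the scatter)) and methyl in place of hydrogen (a 1.3-fold higher number from compound 2 to compound 4 (0.10 log units; within the scatter)) both stay within the scatter in this assay. Hydrogen, chloro and methyl on this aromatic carbon, para to a large group, therefore cannot be told apart on this read-out. No measurement shown gives a cause for this.

Still open, from the compounds shown here alone, is whether an amine, a carboxylic acid or a longer chain at this place would shift the number beyond the scatter. Other places on the shared core also remain untested by any single-place step.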